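Thioether Variations on a Shared Core in a Cell Assay

The compounds below may be only part of what the source reports. "The series", "measured", "known", "first", "only" and "open" are said of these compounds alone.

Measured compounds:
compound 1, `Cc1cc(Nc2cc(-c3cccs3)[nH]n2)n2nc(SCc3ccc(Br)cc3)nc2n1`: 5370 nM
compound 2, `Cc1cc(Nc2cc(-c3ccccc3)[nH]n2)n2nc(SCC(=O)c3ccccc3)nc2n1`: 5240 nM

Of the compounds shown here, two built on the same core have been tested in a functional assay on MCF7 cells (Homo sapiens) for inhibition, read by MTT assay, with a stated time of 72 h; a lower number here means a stronger inhibitor, a higher number a weaker inhibitor. Compound 1 gives 5370 nM, and compound 2 gives 5240 nM. The two numbers sit within the usual scatter of each other, so neither compound can be said to be stronger or weaker than the other on this evidence; both are modest inhibitors of cell growth.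

The next compound, compound 3, `Cc1cc(Nc2cc(-c3ccccc3)[nH]n2)n2nc(SCc3cccc4ccccc34)nc2n1`, keeps everything in compound 2 except one group on the thioether arm. The change is naphthalen-1-yl in place of benzoyl on a saturated chain carbon bound to a sulfur. For the measured compounds named here, no measured pair differs in a single place, so there is no directly comparable step to lean on. What is known is that compound 1, which carries a different aryl-methyl group on the same sulfur, gives 5370 nM, a number close to that of compound 2.

Compound 3 is therefore expected to land near its two neighbours, with a step from compound 2 of a 1.2-fold lower number from compound 2 to compound 3 (0.07 log units; within the scatter) that is expected to be no larger than the scatter. The estimate for compound 3 in this assay is 4500 nM, within a range from 1500 nM to 13000 nM.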

Compound 3, half-maximal inhibitory concentration: 7560 nM
For compound 3 the middle estimate is 1.7-fold (0.23 log units) below the measured one, within the range that was stated.
By their numbers in this assay, from the lowest: compounds 2, 1 and 3 (each within the scatter of the next).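

For the compounds shown here, compound 2 and compound 3 form the first pair here that differs in a single place, so the effect of changing the thioether arm can now be read directly. In this assay putting naphthalen-1-yl in place of benzoyl on a saturated chain carbon bound to a sulfur gives a 1.4-fold higher number from compound 2 to compound 3 (0.16 log units; within the scatter) and so does not separate the two groups, even though the exchange removes a carbonyl with its hydrogen-bond acceptor and brings in a second six-membered aromatic ring. No further measurements accompany this result to help interpret it.

On these data alone, with a single exchange to go on, it remains open whether this place accepts many different groups or whether benzoyl and naphthalen-1-yl merely happen to give similar numbers. An amine or a carboxylic acid on the same saturated chain carbon, or a longer chain there, would show whether any group at this place can move the number in this assay beyond the scatter.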